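Swapping One Halogen on the Aryl Ring of Compound 1

The compounds below may be only part of what the source reports. "The series", "measured", "known", "first", "only" and "open" are said of these compounds alone.

Compound 1 `CC(c1ccc(-c2ccccc2)c(F)c1)c1nnc2n1N=C(c1ccc(Cl)cc1)CS2`: 6100 nM
Compound 2 `CC(C)Cc1ccc(C(C)c2nnc3n2N=C(c2ccc(Br)cc2)CS3)cc1`: 8900 nM
Compound 3 `COc1ccc2cc(C(C)c3n[nH]c(=S)n3N)ccc2c1`: "not active" (no number reported)

In a functional assay on Mahlavu cells (Homo sapiens) for inhibition, read by sulforhodamine B assay, with a stated time of 72 h (on this read-out lower numbers stand for stronger inhibition and higher numbers for weaker inhibition), compound 1 gives the lower of the two numbers reported, but compound 2 sits within the usual scatter of that result, so the two cannot be ranked. Compound 3 carries no number at all. Compound 4 `CC(c1ccc(-c2ccccc2)c(F)c1)c1nnc2n1N=C(c1ccc(F)cc1)CS2` has not been measured; it differs from compound 1 in one place: fluoro in place of chloro on an aromatic carbon. Among the compounds with values here, no pair of measured compounds shows this change, so its effect here is unknown. The change exchanges one heavy atom for one heavy atom, with no ring and no change in donors or acceptors. The step of a 1.3-fold higher number from compound 1 to compound 4 (0.12 log units; within the scatter) is expected to be small, at most a modest weakening. Compound 4 is therefore estimated at 8000 nM, with a range of 3000 nM to 20000 nM.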

Compound 4, half-maximal inhibitory concentration: 7400 nM
Compound 4: middle estimate off by 1.1-fold (0.03 log units), on the high side; the range from low to high includes it.
By their numbers in this assay, from the lowest: compounds 1, 4 and 2 (each within the scatter of the next).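

Within the data shown here, at this position, on a 4-chlorophenyl ring in this assay, exchanging chloro for fluoro gives the first direct comparison of the two halogens (a 1.2-fold higher number from compound 1 to compound 4 (0.08 log units; within the scatter)). Compound 1 and compound 4 cannot be told apart, so chloro and fluoro are interchangeable here as far as this read-out can show. No other measurement bears on why this exchange has so little effect.

Still open, going by these compounds, is whether this position accepts anything other than a halogen. An amine or a carboxylic acid in place of the chloro is not among the compounds shown.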